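This account rests on a few compounds, and the source may have more. Where it says the series, first, only, none or still open, it means among the compounds named here.

In a functional assay on the whole organism (strain albino) for inhibition, with Rattus norvegicus as the target, read by paw edema, with stated times of 30 min and 2 h, at a dose of 0.28 mmol/kg by the oral route (a lower number here means less inhibition, a higher number more inhibition at the dose given (going by the name of the read-out)), compound 1 `C=CCn1c(SCC(=O)Nc2ccc(C(C)=O)cc2)nnc1-c1ccccc1` gives 52%, compound 2 `C=CCn1c(SCC(=O)Nc2ccc(/C(C)=N/O)cc2)nnc1-c1ccccc1` gives 63%, and compound 3 `CCn1c(SCC(=O)Nc2ccc(/C(C)=N/O)cc2)nnc1-c1ccc(OC)c(OC)c1` gives 65%. Compound 3 thus holds the highest of the three numbers, though its gap to compound 2 lies within the scatter. Within the data shown here, the one measured step, a number 11 percentage points higher from compound 1 to compound 2 (beyond the scatter), concerns the group on the anilide side and says nothing about the aryl on the shared core. Among the measured compounds shown here, compound 4 `CCn1c(SCC(=O)Nc2ccc(/C(C)=N/O)cc2)nnc1-c1ccc(OC)cc1` differs from compound 3 by hydrogen in place of methoxy on an aromatic carbon on that aryl, a change for which no step has been measured. The step from compound 3 to compound 4 in this assay is therefore expected to be small, a number 5 percentage points lower from compound 3 to compound 4 (within the scatter). Compound 4 is estimated at 60%, with a range from 48% to 72%.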

Compound 4, a percentage reported as inhibition, in the whole organism at one dose (the size of the read-out at that dose, not a potency): 58%
For compound 4 the middle estimate is 2 percentage points above the measured one, within the range that was stated.
By their numbers in this assay, from the lowest: compounds 1, 4, 2 and 3 (each within the scatter of the next, the first and the last beyond it).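

The first step read on the aryl of the shared core, from 3,4-dimethoxyphenyl to 4-methoxyphenyl, is in this assay a number 7 percentage points lower from compound 3 to compound 4 (within the scatter). This methoxy group can therefore give way to hydrogen without the read-out separating the two compounds, provided the other methoxy group stays in place. Nothing at hand accounts for this result.

The compounds shown leave open what a hydroxy group or a chlorine atom would give on this aromatic carbon. They also leave open what an unsubstituted phenyl would give alongside the ethyl group and the oxime.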